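The compounds below may be only part of what the source reports. "The series", "measured", "known", "first", "only" and "open" are said of these compounds alone.

Of the compounds shown here, three built on a shared core have been measured in a physicochemical assay for solubility, in phosphate buffer, with a stated time of 2 h; a higher number here means a more soluble compound, a lower number a less soluble compound. Compound 1 `C/C(=N\NC(=N)N)c1sc(-c2ccc(-c3ccccc3)cc2)nc1C` gives 2700 nM, compound 2 `Cc1nc(-c2ccc(-c3ccccc3)cc2)sc1-c1nnc(N2CCN(C)CC2)o1` gives 45000 nM and compound 3 `Cc1nc(-c2ccc(-c3ccccc3)cc2)sc1-c1nnc(NN)o1` gives 77000 nM. Compound 3 therefore sits in the upper pair of these numbers. Its nearest neighbour is separated by a 1.7-fold higher number from compound 2 to compound 3 (0.23 log units; within the scatter), which lies within the scatter, while its furthest is separated by a 29-fold higher number from compound 1 to compound 3 (1.46 log units; beyond the scatter), a large step beyond the scatter.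

Compound 4 `CNC(=N)Nc1nnc(-c2sc(-c3ccc(-c4ccccc4)cc3)nc2C)o1` departs from compound 3 by one change: a group of 4 heavy atoms (2 carbon, 2 nitrogen; no ring) in place of one nitrogen atom, on a nitrogen on an aromatic ring. A group of 4 heavy atoms, without a ring, stands in place of one nitrogen atom, on a nitrogen on an aromatic ring.

For the measured compounds named here, no measured step makes this exact change, so the evidence is indirect. The exchange of one end group for another in a 1.7-fold higher number from compound 2 to compound 3 (0.23 log units; within the scatter) stayed within the scatter, which argues against a large move. Compound 4 also keeps the ring that compound 1 lacks, so the large 29-fold higher number from compound 1 to compound 3 (1.46 log units; beyond the scatter) is not expected to repeat in full. A modest move to a lower number is expected, estimated as a 2.6-fold lower number from compound 3 to compound 4 (0.41 log units; beyond the scatter). In this assay the estimate for compound 4 is 30000 nM, with an expected range from 8000 nM to 90000 nM.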

Compound 4, solubility: 89000 nM
The estimate for compound 4 lay 3.0-fold (0.47 log units) below the measured number; low and high end bracket the measured number.
By their numbers in this assay, from the lowest: compound 1; then compounds 2, 3 and 4 (each within the scatter of the next).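

At this position, on a nitrogen on an aromatic ring, a group of 4 heavy atoms with 1 double bond outside aromatic rings stands where compound 3 has amino, and in this assay the result is a 1.2-fold higher number from compound 3 to compound 4 (0.06 log units; within the scatter), so the larger group carries no change that can be told from the scatter. Compared with the 4-methylpiperazin-1-yl end group of compound 2, the same open-chain group gives a 2.0-fold higher number from compound 2 to compound 4 (0.30 log units; within the scatter), which also stays within the scatter, so this assay does not separate the open chain from the 4-methylpiperazin-1-yl group. No measurement shown here gives a reason for how little these end groups separate.

From the compounds shown here alone, the end groups compared here all carry nitrogen, so it remains open whether a carboxylic acid, a simple alkyl chain or an ether in the same place would also stay within the scatter of compound 3. Going by these compounds, it also remains open whether a longer chain of the kind seen in compound 4 would hold the number in this assay or move it beyond the scatter.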